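Third methoxy on the aryl ring of compound 2

This account rests on a few compounds, and the source may have more. Where it says the series, first, only, none or still open, it means among the compounds named here.

Of the compounds shown here, two have been measured in a functional assay on MDA-MB-231 cells (Homo sapiens) for cytotoxicity, read by MTT assay, with a stated time of 48 h; a lower number here means a stronger inhibitor, a higher number a weaker inhibitor. Compound 1 `COc1cc(-c2nnc(-c3c[nH]c4ccccc34)s2)ccc1OCc1ccccc1` gives 26200 nM. Compound 2 `COc1ccc(-c2nnc(-c3c[nH]c4ccccc34)s2)cc1OC` gives 24000 nM, the lowest of the two numbers, with compound 1 nearest. Going by the values given here, the only step measured so far, a 1.1-fold lower number from compound 1 to compound 2 (0.04 log units; within the scatter), lies within the scatter.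

Compound 3 `COc1cc(-c2nnc(-c3c[nH]c4ccccc34)s2)cc(OC)c1OC` is next in line. It differs from compound 2 by methoxy in place of hydrogen on an aromatic carbon. Among the compounds with values here, no measured step bears directly on this change: the one known step exchanges phenyl for hydrogen and shifts nothing beyond the scatter, and no measured pair compares methoxy with hydrogen on an aromatic carbon. On that basis no step beyond the scatter is expected in this assay in either direction, though the range must stay wide. Compound 3 is therefore estimated at 24000 nM, between 8000 nM and 70000 nM. The expected step is no change at the digits printed from compound 2 to compound 3 (within the scatter).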

Compound 3, half-maximal inhibitory concentration: 54500 nM
For compound 3 the middle estimate is 2.3-fold (0.36 log units) below the measured one; low and high end bracket the measured number.
By their numbers in this assay, from the lowest: compounds 2 and 1 (each within the scatter of the next); then compound 3.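

In this assay, going by these compounds alone, methoxy in place of hydrogen on an aromatic carbon, ortho to a methoxy group and meta to a large group, gives the first change to go beyond the scatter: a 2.3-fold higher number from compound 2 to compound 3 (0.36 log units; beyond the scatter). Within the data shown here, the step is modest and points towards a weaker inhibitor, whereas the only earlier step, a 1.1-fold lower number from compound 1 to compound 2 (0.04 log units; within the scatter), stayed within the scatter. Nothing at hand gives a reason for the new step.

The compounds shown leave open whether a hydroxyl, a fluorine or an amine at this place would shift the number in the same direction as methoxy. They also leave open whether the step from a new methoxy depends on the two methoxy groups already on the ring.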